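The compounds below may be only part of what the source reports. "The series", "measured", "known", "first", "only" and "open" are said of these compounds alone.

Working notes on the series.

The measure throughout is a functional assay on NCI-H1975 cells (Homo sapiens) for inhibition, read by MTT assay, with a stated time of 72 h; a higher number here means a weaker inhibitor, a lower number a stronger inhibitor. Compound 1, `O=C(CSc1nc(Nc2ccccc2)c2ccccc2n1)Nc1ccccc1Br`, gives 10300 nM in this assay. Compound 2, `C=CC(=O)Nc1cccc(NC(=O)CSc2nc(Nc3ccccc3Cl)c3ccccc3n2)c1`, carries an acrylamide on the aniline of the amide and a chlorine on the other aniline; in this assay compound 2 gives 10000 nM. Against the only other number, that of compound 1, compound 2 sits at the same level, the gap between the two being within the scatter of repeat measurements, so neither can be called the stronger or weaker of the pair. Both compounds share the same core and both are weak inhibitors on these cells.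

Compound 3, `C=CC(=O)Nc1cccc(NC(=O)CSc2nc(Nc3ccc(Cl)c(Cl)c3)c3ccccc3n2)c1`, has not been measured. Its difference from compound 2 is 3,4-dichlorophenyl in place of 2-chlorophenyl on a nitrogen on an aromatic ring. Going by the values given here, no measured pair isolates this change, so the expectation for it rests on the level of compound 2 alone. The step from compound 2 to compound 3 is estimated as a 1.2-fold lower number from compound 2 to compound 3 (0.07 log units; within the scatter), that is, nothing expected beyond the scatter in either direction. For compound 3 the estimate in this assay is 8500 nM, with a range from 3000 nM to 25000 nM.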

Compound 3, half-maximal inhibitory concentration: 19100 nM
For compound 3 the middle estimate is 2.2-fold (0.35 log units) below the measured one; the range from low to high includes it.
By their numbers in this assay, from the lowest: compounds 2, 1 and 3 (each within the scatter of the next).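

Going by these compounds alone, this is the first pair that differs in one place, and it gives a direct reading of the aryl group on this nitrogen. In this assay the change to 3,4-dichlorophenyl from 2-chlorophenyl gives a 1.9-fold higher number from compound 2 to compound 3 (0.28 log units; within the scatter) and so does not separate the two compounds, even though the entering group carries a second chlorine and a different chlorine pattern. At this position, then, these two chlorinated phenyl groups cannot be told apart on these cells, and both compounds remain weak inhibitors. No measurement shown here offers an explanation for this result.

From the compounds shown here alone, both groups compared at this position are chlorinated phenyl rings, so it remains open whether a methoxy or nitrile group on the ring, or an aliphatic amine such as morpholine in place of the ring, would move the number beyond the scatter. Compound 1 and compound 2 differ in more than one place, so the contribution of the acrylamide also stays unresolved, and a matched propanamide would be needed to isolate it.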